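The source may report more compounds than this note shows. Statements on the series, on what has been measured and on what is new or still open speak of the compounds shown alone.

Measured compounds:
Compound 1 `CS(=O)(=O)c1ccc(Nc2ncc(F)c(Nc3nc4ccccc4s3)n2)cc1` gives 3270 nM in a functional assay on HCT-116 cells (Homo sapiens) for antiproliferative activity, read by MTT assay, with a stated time of 48 h; on this read-out higher numbers stand for weaker inhibition and lower numbers for stronger inhibition.
Compound 2 `COc1ccc2nc(Nc3nc(Nc4ccc(S(N)(=O)=O)cc4)ncc3F)sc2c1` gives 11500 nM in this assay.
Compound 3 `COc1ccc2nc(Nc3nc(Nc4ccc(S(C)(=O)=O)cc4)ncc3F)sc2c1` gives 2630 nM in this assay.

Compound 3 has the lowest number of the three, although its gap to compound 1 is within the scatter, so the two cannot be ranked against each other; compound 2 stands clearly higher. The two steps that lead to compound 3 are a 1.2-fold lower number from compound 1 to compound 3 (0.09 log units; within the scatter) and a 4.4-fold lower number from compound 2 to compound 3 (0.64 log units; beyond the scatter). Compound 4 `COc1ccc2nc(Nc3ccnc(Nc4ccc(S(C)(=O)=O)cc4)n3)sc2c1` differs from compound 3 in one place: hydrogen in place of fluoro on an aromatic carbon. Neither measured step touches the fluoro; both concern other parts of the molecule, so there is no direct guide to the size or direction of this change, and any expectation must carry wide margins. This step is expected to be a 2.1-fold higher number from compound 3 to compound 4 (0.32 log units; beyond the scatter), leaning toward a somewhat higher number while allowing for no change. Compound 4 is expected to give about 5500 nM in this assay, with a range from 1500 nM to 20000 nM.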

Compound 4, half-maximal inhibitory concentration: 2270 nM
For compound 4 the middle estimate is 2.4-fold (0.38 log units) above the measured one, and the stated range covers the measured number.
By their numbers in this assay, from the lowest: compounds 4, 3 and 1 (each within the scatter of the next); then compound 2.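

Hydrogen in place of fluoro on this aromatic carbon gives a 1.2-fold lower number from compound 3 to compound 4 (0.06 log units; within the scatter) in this assay and so leaves compound 3 and compound 4 impossible to rank against each other. Among the compounds shown here, this is the first measured change at this position, as the earlier steps concerned the methoxy and the group on the sulfonyl sulfur, and in this one pair the fluoro can give way to hydrogen with no readable change in antiproliferative activity. Nothing available explains this result.

As far as these compounds go, whether a larger group on the same carbon, such as chloro, methyl or an amine, would move the number beyond the scatter remains open. Also open, from the compounds shown here alone, is whether the same exchange would be equally silent without the methoxy, or with amino on the sulfonyl sulfur.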